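Bromo to Methyl Repeated on a Second Core

The source may hold more compounds than are shown below. What is called first, only, known or untested is meant among the compounds shown, and "the series" means these compounds.

Compound 2 `O=C1CSC(N2N=C(c3ccc(Br)cc3)CC2c2ccc3ccccc3c2)=N1` and compound 1 `Cc1ccc(C2=NN(C3=NC(=O)CS3)C(c3ccc4ccccc4c3)C2)cc1` share one core and differ by methyl in place of bromo on an aromatic carbon. In a functional assay on HepG2 cells (Homo sapiens) for inhibition, read by CCK-8 assay, with a stated time of 48 h (a higher number here means a weaker inhibitor, a lower number a stronger inhibitor), compound 2 gives 18200 nM, and compound 1 gives 12700 nM; the step is a 1.4-fold lower number from compound 2 to compound 1 (0.16 log units; within the scatter). Compound 3 `O=C1CSC(N2N=C(c3ccc(Br)cc3)CC2c2cccc3ccccc23)=N1` is built on a different core; how it differs from the core of compound 2 is not broken down here. In this assay compound 3 gives 13400 nM. Compound 4 `Cc1ccc(C2=NN(C3=NC(=O)CS3)C(c3cccc4ccccc34)C2)cc1` is made from compound 3 by the same change, (methyl in place of bromo on an aromatic carbon), at the same place. Because that change earlier gave a 1.4-fold lower number from compound 2 to compound 1 (0.16 log units; within the scatter), compound 4 is expected to show a 1.4-fold lower number from compound 3 to compound 4 (0.15 log units; within the scatter). Compound 4 is therefore estimated at 9500 nM in this assay, with a likely range from 5000 nM to 18000 nM.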

Compound 4, half-maximal inhibitory concentration: 8660 nM
Compound 4: the middle estimate sits 1.1-fold (0.04 log units) above what was measured; the measured number falls inside the stated range.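

In this assay the change from 4-bromophenyl to 4-methylphenyl gives a 1.5-fold lower number from compound 3 to compound 4 (0.19 log units; within the scatter). Set beside the earlier step, the change carries over from one core to the other with no difference that can be told apart: the same change on two cores in this assay, a 1.4-fold lower number (0.16 log units; within the scatter) from compound 2 to compound 1 and a 1.5-fold lower number (0.19 log units; within the scatter) from compound 3 to compound 4, 1.1-fold (0.03 log units) apart, within the scatter of two such steps. For the compounds shown here, both steps lie within the scatter, however, so the pair shows only that the swap leaves the number about where it stood on these two cores; it does not show a real gain from methyl on either core, nor a rule for the whole series.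

The compounds shown carry only bromo and methyl at this place. Going by these compounds, it remains open whether an amine, a carboxylic acid or a methoxy group there would move the number beyond the scatter on either core.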